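Trifluoromethyl to 1H-pyrazol-3-yl on the carbonyl carbon

The source may hold more compounds than are shown below. What is called first, only, known or untested is meant among the compounds shown, and "the series" means these compounds.

Three compounds sharing one core have been run in an ADME assay on microsomes (Homo sapiens) for metabolic stability (a higher number here means that the compound lasts longer, a lower number that the compound disappears faster), and none returns a number. Compound 2 (`O=C(C1CCN(C(=O)C(F)(F)F)CC1)N1N=CCC1c1ccccc1`) gives > 1.5 h, which is a limit. Compound 3 (`CC(=O)N1CCC(C(=O)N2N=CC[C@H]2c2ccccc2)CC1`) gives > 2.75 h, also a limit. Compound 1 (`O=C(c1cnco1)N1CCC(C(=O)N2N=CC[C@H]2c2ccccc2)CC1`) carries 1,3-oxazol-5-yl on the carbonyl carbon and gives > 3 h, again a limit. Compound 2 therefore stands on a limit only, as do the other two, and no order can be read among them.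

Compound 4 (`O=C(c1cc[nH]n1)N1CCC(C(=O)N2N=CCC2c2ccccc2)CC1`) has not been measured. It differs from compound 2 by 1H-pyrazol-3-yl in place of trifluoromethyl on a carbonyl carbon. For the measured compounds named here, one measured step bears on this place, a step that the two limits leave unreadable from compound 1 to compound 3, and it gives no size to carry over. The nearest guide is compound 1, a five-membered aromatic group on the same carbonyl carbon, with its limit of > 3 h.

The estimated step that the limit leaves unreadable from compound 2 to compound 4 is not expected to read beyond the scatter in this assay. Compound 4 is expected at 2.8 h, with an estimated range of 1.4 h to 5.5 h, and it may well be reported as a limit.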

Compound 4, half-life: > 2.75 h
Compound 4: no number, only a limit; the forecaster's own chance of this, stated with the estimate: 75%; the middle value is on the limit's open side.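

Compound 2 and compound 4 both return only limits in this assay, and no step can be read between them. The compounds shown leave open how long any of them actually lasts, and whether trifluoromethyl, methyl, 1,3-oxazol-5-yl and 1H-pyrazol-3-yl on the carbonyl carbon differ at all in this assay.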